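Removing the benzyl group from a coumarin propargylamine

The compounds below may be only part of what the source reports. "The series", "measured", "known", "first", "only" and "open" are said of these compounds alone.

Three compounds of one family, sharing the core of compound 1 `C#CCN(CCCCOc1ccc2ccc(=O)oc2c1)Cc1ccc(C(C)C)cc1`, have been measured in an ADME assay on isolated protein for inhibition of Amine oxidase [flavin-containing] A (Homo sapiens), read by fluorescence and Amplex Red, with stated times of 15 min and 20 min; on this read-out higher numbers stand for weaker inhibition and lower numbers for stronger inhibition. Compound 1 gives 35400 nM. Compound 3 `C#CCN(CCCOc1ccc2ccc(=O)oc2c1)Cc1ccccc1` gives 38600 nM, and compound 2 `C#CCN(CCCOc1ccc2ccc(=O)oc2c1)Cc1ccc(F)c(F)c1` gives 49200 nM; both numbers fall within the usual scatter of the number for compound 1, so no order among the three can be read from them. Within the data shown here, the one single-point step, a 1.3-fold lower number from compound 2 to compound 3 (0.11 log units; within the scatter), shows that swapping the substitution pattern of the aryl part of the benzyl group hardly moves this read-out.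

Compound 4 `C#CCN(C)CCCCOc1ccc2ccc(=O)oc2c1` is not yet measured. It differs from compound 1 by hydrogen in place of 4-isopropylphenyl on a saturated chain carbon bound to an amine nitrogen. Among the measured compounds shown here, no measured step removes the aryl group altogether, so the step from compound 2 to compound 3 bears on it only loosely, and it stayed within the scatter. For compound 4 a somewhat higher number is expected, the step from compound 1 being a 1.6-fold higher number from compound 1 to compound 4 (0.19 log units; within the scatter), but with wide uncertainty. Compound 4 is estimated at 55000 nM, ranging from 20000 nM to 150000 nM.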

Compound 4, half-maximal inhibitory concentration: 3280 nM
Beside the measured number, compound 4's estimate is 17-fold (1.22 log units) above it; the whole stated range lies above it.
By their numbers in this assay, from the lowest: compound 4; then compounds 1, 3 and 2 (each within the scatter of the next).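

In this assay, cutting 4-isopropylbenzyl back to methyl gives an 11-fold lower number from compound 1 to compound 4 (1.03 log units; beyond the scatter), so stronger inhibition comes with the loss of the whole aromatic ring. Among these compounds, the only earlier step, a 1.3-fold lower number from compound 2 to compound 3 (0.11 log units; within the scatter), changed just the fluorine substitution on that ring and stayed within the scatter, so it could not show that this position responds strongly once the ring itself is removed. Nothing available here explains the size of this step.

The compounds shown leave open whether ethyl or a plain hydrogen in place of the methyl of compound 4 would keep, extend or lose this gain, and whether an unsubstituted benzyl group on this chain would read like compound 1. They also leave open whether the same change would have a similar effect on a longer chain.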